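The compounds below may be only part of what the source reports. "The series", "measured", "known", "first", "only" and "open" are said of these compounds alone.

Measured so far in a functional assay on BV-2 cells (Mus musculus), read by Griess assay, with a stated time of 24 h; on this read-out higher numbers stand for weaker inhibition and lower numbers for stronger inhibition:

- compound 1 (`C=CCCC1COC2(C=CC(=O)C=C2)N(c2ccccc2)C1=O`) gives 730 nM
- compound 2 (`O=C1C=CC2(C=C1)OCC(Cc1ccc(C(F)(F)F)cc1)C(=O)N2c1ccccc1`) gives 1650 nM

Compound 2 holds the higher of these two numbers, which makes it the weaker inhibitor of the pair. Going by the values given here, the only measured step is a 2.3-fold higher number from compound 1 to compound 2 (0.35 log units; beyond the scatter), in which 4-(trifluoromethyl)phenyl stands in place of allyl. It is modest, though beyond the scatter.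

The next compound is compound 3 (`O=C1C=CC2(C=C1)OCC(Cc1ccc([N+](=O)[O-])cc1)C(=O)N2c1ccccc1`), which has nitro in place of trifluoromethyl on an aromatic carbon. The rest of the structure stays the same. Among the compounds with values here, no measured step swaps a group at this place, so the data offer no direct guide. The step to compound 2 bears on it only loosely: exchanging the whole allyl group moved the number modestly, and here only the group on the aromatic ring changes. No shift beyond the scatter is therefore expected, in either direction. The expected change is a 1.1-fold lower number from compound 2 to compound 3 (0.04 log units; within the scatter), close to no change at all. Compound 3 is estimated at 1500 nM, with an expected range from 650 nM to 3500 nM.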

Compound 3, half-maximal inhibitory concentration: 430 nM
Compound 3: middle estimate off by 3.5-fold (0.54 log units), on the high side; the measured number lies below the stated range.
By their numbers in this assay, from the lowest: compounds 3 and 1 (each within the scatter of the next); then compound 2.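

In this assay, the group carried on the aromatic ring of the side chain clearly matters: with the rest of the structure unchanged, nitro in place of trifluoromethyl, on an aromatic carbon para to a large group, gives a 3.8-fold lower number from compound 2 to compound 3 (0.58 log units; beyond the scatter) and is a larger shift than the one seen when allyl gave way to 4-(trifluoromethyl)phenyl. The comparison with the allyl compound adds a second point, since 4-nitrophenyl in place of allyl gives a 1.7-fold lower number from compound 1 to compound 3 (0.23 log units; within the scatter) and so does not separate the two compounds, which means that an aromatic ring on this chain does not by itself go with a weaker number: compound 2 has one, and so does compound 3. Nothing measured here explains why trifluoromethyl and nitro part ways at this place.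

On these data alone, with only these two groups on the ring, it remains open how others at the same place, such as an amine, a carboxylic acid or a nitrile, would read in this assay. As far as these compounds go, it is also open whether a longer chain in place of allyl would keep the number of compound 1 or shift it.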